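A few compounds are considered here, and "the series" means these few. Any claim that something is new, unique, unknown or untested is made for them only; others in the source may bear on it.

In a functional assay on Z-138 cells (Homo sapiens) for antiproliferative activity, with a stated time of 72 h (on this read-out lower numbers stand for stronger inhibition and higher numbers for weaker inhibition), compound 1 `Nc1ncnn2c([C@@H]3O[C@H](CO)[C@@H](O)[C@H]3O)cc(C#CC3CC3)c12` gives 20 nM, compound 2 `Nc1ncnn2c([C@@H]3O[C@H](CO)[C@@H](O)[C@H]3O)cc(C#Cc3ccc(F)cc3)c12` gives 89000 nM, and compound 3 `Nc1ncnn2c([C@@H]3O[C@H](CO)[C@@H](O)[C@H]3O)cc(C#Cc3ccccc3)c12` gives 41400 nM. Compound 3 therefore sits in the middle of the three, close to compound 2 and far from compound 1. The next structure, compound 4 `Nc1ncnn2c([C@@H]3O[C@H](CO)[C@@H](O)[C@H]3O)cc(-c3ccc(F)cc3)c12`, has 4-fluorophenyl in place of 2-phenylethynyl on an aromatic carbon.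

Two measured changes at this same carbon were large, a 2100-fold higher number from compound 1 to compound 3 (3.32 log units; beyond the scatter) and a 4500-fold higher number from compound 1 to compound 2 (3.65 log units; beyond the scatter), so the group placed here can matter greatly. The fluoro change alone was modest, a 2.1-fold lower number from compound 2 to compound 3 (0.33 log units; beyond the scatter). Among the compounds with values here, both compounds carrying an aromatic ring on the triple bond gave high numbers, but no measured compound has such a ring without the triple bond. The data therefore give only a weak indication of direction, and a modest move to a lower number is the cautious expectation, with wide uncertainty. The expected step is a 2.8-fold lower number from compound 3 to compound 4 (0.44 log units; beyond the scatter). Compound 4 is estimated at 15000 nM, with an expected range from 800 nM to 100000 nM.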

Compound 4, half-maximal inhibitory concentration: > 100000 nM
Compound 4 gave a limit, no number; the forecaster's own chance of this, stated with the estimate: 15%; middle value at least 6.6-fold (0.82 log units) from the limit.
By their numbers in this assay, from the lowest: compound 1; then compound 3; then compound 2. At a limit, above all of these: compound 4.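

In this assay compound 4 stands at a limit of the assay, not a number: > 100000 nM. Setting the 4-fluorophenyl directly on the aromatic carbon, without the triple bond, did not bring the number down, with an at least 2.4-fold higher number from compound 3 to compound 4 (0.38 log units; beyond the scatter) and an at least 5000-fold higher number from compound 1 to compound 4 (3.69 log units; beyond the scatter). Within the data shown here, the step that removes only the triple bond, an at least 1.1-fold higher number from compound 2 to compound 4 (0.05 log units; that floor lies within the scatter), gives no order, yet all three compounds with an aromatic ring at this position now sit far above the one cyclopropyl compound, with or without the triple bond.

On these data alone, it remains open whether the triple bond matters at all for a non-aromatic group, as a cyclopropyl set directly on the aromatic carbon would test, or whether a longer carbon chain or a terminal amine on the triple bond would keep the low number. How far compound 4 lies past its limit is also unknown: the limit of > 100000 nM in this assay, at which 1 of the 4 values shown sits.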